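Swapping bromo for nitrooxy on two pyrazoline-type cores

This account rests on a few compounds, and the source may have more. Where it says the series, first, only, none or still open, it means among the compounds named here.

Compound 1, `COc1ccc(C2CC(c3ccc(OC)c(OC)c3)=NN2C(=O)CBr)c(OC)c1`, was tested in a functional assay on the whole organism (strain albino) for inhibition, with Rattus norvegicus as the target, read by paw edema, with stated times of 30 min and 1 h, at a dose of 100 mg/kg by the oral route (a higher number here means more inhibition at the dose given (going by the name of the read-out), a lower number less inhibition), where compound 1 gives 53%. Compound 2, `COc1ccc(C2CC(c3ccc(OC)c(OC)c3)=NN2C(=O)CO[N+](=O)[O-])c(OC)c1`, differs from compound 1 by nitrooxy in place of bromo on a saturated chain carbon bound to a carbonyl carbon. In this assay compound 2 gives 38%, so the change made a number 15 percentage points lower from compound 1 to compound 2 (beyond the scatter).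

Compound 3, `COc1ccc(C2=NN(C(=O)C(C)Br)C(c3ccco3)C2)cc1OC`, gives 22% in this assay; the difference between the core of compound 3 and the core of compound 1 is not broken down here. Compound 4, `COc1ccc(C2=NN(C(=O)C(C)O[N+](=O)[O-])C(c3ccco3)C2)cc1OC`, is not yet measured and differs from compound 3 by nitrooxy in place of bromo on a saturated chain carbon bound to a carbonyl carbon and a saturated chain carbon. Among the measured compounds shown here, this is the same kind of change as the one from compound 1 to compound 2, though here the carbon that carries it is also bound to a saturated chain carbon.

Because the earlier change made a number 15 percentage points lower from compound 1 to compound 2 (beyond the scatter), a step of similar size is expected, a number 12 percentage points lower from compound 3 to compound 4 (beyond the scatter), and compound 4 is estimated at 10%, between 0% and 25%.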

Compound 4, a percentage reported as inhibition, in the whole organism at one dose (the size of the read-out at that dose, not a potency): 35%
Compound 4: the middle estimate sits 25 percentage points below what was measured; measured number above the stated range.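

Putting nitrooxy in place of bromo gave a number 13 percentage points higher from compound 3 to compound 4 (beyond the scatter), the opposite direction to a number 15 percentage points lower from compound 1 to compound 2 (beyond the scatter). In this assay the swap therefore does not carry over from one core to the other with a steady size or direction: the same change on two cores in this assay, a number 15 percentage points lower (beyond the scatter) from compound 1 to compound 2 and a number 13 percentage points higher (beyond the scatter) from compound 3 to compound 4, 28 percentage points apart, beyond the scatter of two such steps

The two pairs differ in the core and also in the saturated chain carbon on the carbon that carries the group, and these pairs cannot show which of the two matters.

On these data alone, it remains open how 1-bromoethyl and 1-(nitrooxy)ethyl would compare on the core of compound 1. Also open, as far as these compounds go, is how an amine or a carboxylic acid in the place of bromo would read on either core.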